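The source may report more compounds than this note shows. Statements on the series, on what has been measured and on what is new or still open speak of the compounds shown alone.

Measured in a functional assay on U2OS cells (Homo sapiens) for cytotoxicity, read by MTT assay, with a stated time of 48 h; on this read-out higher numbers stand for weaker inhibition and lower numbers for stronger inhibition:
Compound 1 `Fc1cccc(-c2nc(Nc3cccc(Cl)c3)c3cc(F)ccc3n2)c1` gives > 50000 nM, which is a limit of the assay and not a number.
Compound 2 `Oc1ccccc1Nc1nc(-c2cccc(F)c2)nc2ccc(F)cc12` gives 41400 nM.
Compound 3 `Nc1ccccc1Nc1nc(-c2cccc(F)c2)nc2ccc(F)cc12` gives 37900 nM.

Compound 1 therefore stands only at a limit, the single one of the three values at the limit of > 50000 nM in this assay, at which 1 of the 3 values shown sits, so its position is known only as a floor. Compound 4 `Cc1cccc(Nc2nc(-c3cccc(F)c3)nc3ccc(F)cc23)c1` differs from compound 1 by methyl in place of chloro on an aromatic carbon. Going by the values given here, no measured step swaps chloro for methyl. The steps that replaced the whole 3-chlorophenyl group, an at least 1.2-fold lower number from compound 1 to compound 2 (0.08 log units; that floor lies within the scatter) and an at least 1.3-fold lower number from compound 1 to compound 3 (0.12 log units; that floor lies within the scatter), were small. Compound 4 is therefore expected to show a number no higher from compound 1 to compound 4 (the limit leaves the size open), no step beyond the scatter. For compound 4 the estimate is 50000 nM, in the range 25000 nM to 100000 nM, most likely again at the limit.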

Compound 4, half-maximal inhibitory concentration: > 50000 nM
Compound 4: no number, only a limit (the forecaster's own chance of this, stated with the estimate: 60%); the middle value sits exactly at the limit.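

Methyl in place of chloro on this aromatic carbon leaves compound 4 at a limit of the assay, as compound 1 is, and the step between them cannot be read because both sit at that limit: the limit of > 50000 nM in this assay, at which 2 of the 4 values shown sit.
The two readable comparisons give an at least 1.3-fold higher number from compound 3 to compound 4 (0.12 log units; that floor lies within the scatter) and an at least 1.2-fold higher number from compound 2 to compound 4 (0.08 log units; that floor lies within the scatter), so neither separates the compounds.
Thus, neither chloro nor methyl here yields a measured number.

On these data alone, it stays open whether an amine or a carboxylic acid in place of chloro on this aromatic carbon would give a readable number.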